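Methyl on the core: expected effect in the rat assay

This account rests on a few compounds, and the source may have more. Where it says the series, first, only, none or still open, it means among the compounds named here.

Compound 1 `CC1CCC(=NNc2ccccc2)c2ncc(C(=O)O)c(=O)n21` is the reference point. Among the compounds with values here, in a functional assay on the whole organism with Rattus norvegicus as the target (a lower number here means that less compound is needed, a higher number that more compound is needed for the effect), compound 1 gives 0.6 umol/kg, the second highest of the three numbers known. Compound 2 `CC1CCC(=NNc2ccccc2C(=O)O)c2ncc(C(=O)O)c(=O)n21` gives 0.48 umol/kg; the step of a 1.3-fold lower number from compound 1 to compound 2 (0.10 log units; within the scatter) stays within the scatter. Compound 3 `CC1CCC(=NNc2cc(Cl)cc(Cl)c2)c2ncc(C(=O)O)c(=O)n21` gives 13.3 umol/kg; the step of a 22-fold higher number from compound 1 to compound 3 (1.35 log units; beyond the scatter) is large and beyond the scatter.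

Compound 4 `Cc1nc2n(c(=O)c1C(=O)O)C(C)CCC2=NNc1ccccc1` differs from compound 1 in one place: methyl in place of hydrogen on an aromatic carbon. The change sits on the core, next to the ring nitrogen and ortho to the carboxy group, away from the phenyl on the amine nitrogen where both measured steps were made. Neither step bears directly on it: a 1.3-fold lower number from compound 1 to compound 2 (0.10 log units; within the scatter) shows a small addition elsewhere moving the number within the scatter, while a 22-fold higher number from compound 1 to compound 3 (1.35 log units; beyond the scatter) concerns the phenyl alone. With no measured change on the core, the step of a 1.3-fold higher number from compound 1 to compound 4 (0.12 log units; within the scatter) is expected to be none beyond the scatter, with a wide range. Compound 4 is estimated at 0.8 umol/kg in this assay, expected between 0.3 umol/kg and 2.5 umol/kg.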

Compound 4, dose for 50% inhibition: > 100 umol/kg
Compound 4: only a limit was reported (the forecaster's own chance of this, stated with the estimate: 5%); middle value at least 120-fold (2.09 log units) away from the limit.
By their numbers in this assay, from the lowest: compounds 2 and 1 (each within the scatter of the next); then compound 3. At a limit, above all of these: compound 4.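

In this assay compound 4 gives > 100 umol/kg, which is a limit of the assay and not a number: the limit of > 100 umol/kg in this assay, at which 1 of the 4 values shown sits. Both earlier steps were made on the phenyl on the amine nitrogen, and this one shows that the shared core also matters, since methyl in place of hydrogen on this aromatic carbon, ortho to a carboxy group, gives an at least 160-fold higher number from compound 1 to compound 4 (2.22 log units; beyond the scatter). Of the two groups shown on this carbon, only hydrogen keeps the number low.

From the compounds shown here alone, whether any other group is accepted on this carbon stays open; a fluorine, a hydroxyl or an amine would each test this. Also open, going by these compounds, are the actual number for compound 4 and whether methyl here has the same effect when combined with the 3,5-dichlorophenyl of compound 3.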